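A new ring group on a carbonyl carbon

This account rests on a few compounds, and the source may have more. Where it says the series, first, only, none or still open, it means among the compounds named here.

In an ADME assay on microsomes from liver (Mus musculus) for metabolic stability, read by LC-MS, with a stated time of 30 min, tested at 1 uM (a lower number here means that less of the compound is left, a higher number that more of the compound is left), compound 3 `O=C(NCc1ccc(S(=O)(=O)c2ccccc2)cc1)c1cn2ccnc2cn1` gives 13% and sits within the scatter of the two other measured compounds: compound 1 `Cc1ccccc1S(=O)(=O)c1ccc(CNC(=O)c2cc3cnccc3[nH]2)cc1` gives 15% and compound 2 `O=C(NCc1ccc(S(=O)(=O)c2ccccc2)cc1)c1ccc2nccn2c1` gives 18% in the same test. Compound 4 `O=C(NCc1ccc(S(=O)(=O)c2ccccc2)cc1)c1cc2cnccc2[nH]1` changes the group on the carbonyl carbon, and a group of 9 heavy atoms (7 carbon, 2 nitrogen; one five-membered aromatic ring with 1 hetero atom, one six-membered aromatic ring with 1 hetero atom) in place of a group of 9 heavy atoms (6 carbon, 3 nitrogen; one five-membered aromatic ring with 2 hetero atoms, one six-membered aromatic ring with 2 hetero atoms), on a carbonyl carbon describes that change. For the measured compounds named here, the one measured exchange at this place gave a number 5 percentage points lower from compound 2 to compound 3 (within the scatter) and so offers no sign of a large step. Compound 1 carries the entering group on a core of its own and stands at 15% with no gap beyond the scatter. The expected step is therefore small, a number 2 percentage points higher from compound 3 to compound 4 (within the scatter) and no more than scatter. For compound 4 the estimated value is 15% with an expected range from 5% to 30% in this test.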

Compound 4, percent of the compound remaining: 54%
For compound 4 the middle estimate is 39 percentage points below the measured one, and the stated range ends below it.
By their numbers in this assay, from the lowest: compounds 3, 1 and 2 (each within the scatter of the next); then compound 4.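

In this assay the group on the carbonyl carbon proves able to shift the result strongly, with a number 41 percentage points higher from compound 3 to compound 4 (beyond the scatter) and also a number 36 percentage points higher from compound 2 to compound 4 (beyond the scatter) even though the earlier exchange here stayed within the scatter. The entering group alone does not secure this gain, since hydrogen in place of methyl on an aromatic carbon gives a number 39 percentage points higher from compound 1 to compound 4 (beyond the scatter) on the core of compound 1. No measurement shown explains these steps. Still open, on these data alone, is whether a fluorine or a methoxy group in place of that hydrogen would keep the higher number.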